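Methoxy returns in place of bromo on the shared core

A few compounds are considered here, and "the series" means these few. Any claim that something is new, unique, unknown or untested is made for them only; others in the source may bear on it.

Three compounds share one core and differ only in the ring at its end. Compound 1 `c1ccc(-c2cn3ccnc3c(-c3ccc4ncn(C5CCCCC5)c4c3)n2)cc1` gives 38.2% in a functional assay on M14 cells (Homo sapiens) for inhibition, read by sulforhodamine B assay, with a stated time of 48 h, tested at 10 uM; a higher number here means more inhibition at the concentration tested (going by the name of the read-out), a lower number less inhibition. Compound 2 `COc1ccc(-c2cn3ccnc3c(-c3ccc4ncn(C5CCCCC5)c4c3)n2)cc1` gives 89.2%, and compound 3 `Brc1ccc(-c2cn3ccnc3c(-c3ccc4ncn(C5CCCCC5)c4c3)n2)cc1` gives 26.9%, the lowest of the three numbers. The steps are clear: a number 51 percentage points higher from compound 1 to compound 2 (beyond the scatter), a number 11.3 percentage points lower from compound 1 to compound 3 (beyond the scatter) and a number 62.3 percentage points lower from compound 2 to compound 3 (beyond the scatter).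

Compound 4 `COc1ccccc1-c1cn2ccnc2c(-c2ccc3ncn(C4CCCCC4)c3c2)n1` has not yet been measured. It differs from compound 3 as follows: 2-methoxyphenyl in place of 4-bromophenyl on an aromatic carbon. The step that bears on it most directly is the reverse of the large fall from compound 2 to compound 3, since a methoxy group again replaces bromo, while the rise from compound 1 to compound 2 points the same way. The 2-methoxyphenyl of compound 4 is not the ring of compound 2, so the size is less certain. Compound 4 is therefore expected to give 60%, between 30% and 88%, an expected a number 33.1 percentage points higher from compound 3 to compound 4 (beyond the scatter).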

Compound 4, a percentage reported as inhibition, at one concentration (the size of the read-out at that concentration, not a potency): 1.12%
Compound 4: the middle estimate sits 58.9 percentage points above what was measured; the whole stated range lies above it.
By their numbers in this assay, from the lowest: compound 4; then compound 3; then compound 1; then compound 2.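

In this assay the methoxy group brings no gain in itself: where it stands on the phenyl ring decides the outcome, with a number 88.1 percentage points lower from compound 2 to compound 4 (beyond the scatter) when 2-methoxyphenyl replaces 4-methoxyphenyl on the same aromatic carbon of the shared core. Methoxy in place of hydrogen gives a number 51 percentage points higher from compound 1 to compound 2 (beyond the scatter) in the 4-methoxyphenyl form but a number 37.1 percentage points lower from compound 1 to compound 4 (beyond the scatter) in the 2-methoxyphenyl form, so the same replacement can move the number in opposite directions. The 2-methoxyphenyl ring also ends up under the 4-bromophenyl ring, with a number 25.8 percentage points lower from compound 3 to compound 4 (beyond the scatter) and compound 4 therefore has the lowest number of the four.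

As far as these compounds go, it remains open whether an amine or an ethoxy group in place of the methoxy of compound 2 would keep its high number. Nothing available here accounts for the gap between the two methoxyphenyl compounds.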